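The compounds below may be only part of what the source reports. "The series", "measured", "known", "first", "only" and "open" are said of these compounds alone.

Measured so far in an assay on HEK293 cells for agonist activity at transient receptor potential cation channel subfamily M member 8 (Homo sapiens), read by fluorescence and calcium flux, with a stated time of 15 min; on this read-out higher numbers stand for an effect only at larger amounts of compound and lower numbers for an effect already at smaller amounts:
- compound 1 `Cc1ccc(OCC(=O)N(Cc2cccs2)c2ccn(C)n2)cc1`: 855 nM
- compound 2 `Cc1ccc(OCC(=O)N(Cc2cccs2)C2COC2)cc1`: 23000 nM
- compound 3 `Cc1ccc(OCC(=O)N(Cc2cccs2)c2cn[nH]c2)cc1`: 1.4 nM

Compound 3 gives the lowest number of the three in this assay; the nearest is compound 1, a 610-fold lower number from compound 1 to compound 3 (2.79 log units; beyond the scatter), and the furthest is compound 2, a 16000-fold lower number from compound 2 to compound 3 (4.22 log units; beyond the scatter). Both steps lie beyond the scatter.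

Compound 4 `Cc1ccc(OCC(=O)N(CCCO)Cc2cccs2)cc1` has not yet been measured. It differs from compound 3 in one place: 3-hydroxypropyl in place of 1H-pyrazol-4-yl on an amide-type nitrogen.

Going by the values given here, the steps that bear on this change are those from a group without the five-membered ring to the 1H-pyrazol-4-yl group. The step from the oxetan-3-yl group, a 16000-fold lower number from compound 2 to compound 3 (4.22 log units; beyond the scatter), was very large; the step from the 1-methyl-1H-pyrazol-3-yl group, a 610-fold lower number from compound 1 to compound 3 (2.79 log units; beyond the scatter), was also large. Compound 4 carries a chain with no ring on the amide-type nitrogen, as compound 2 carries a ring that is not aromatic, so a large rise in this assay is expected, an 11000-fold higher number from compound 3 to compound 4 (4.03 log units; beyond the scatter). For compound 4 the estimate in this assay is 15000 nM, with a range from 2000 nM to 100000 nM.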

Compound 4, half-maximal effective concentration: 3000 nM
Compound 4: middle estimate off by 5.0-fold (0.70 log units), on the high side; the range from low to high includes it.
By their numbers in this assay, from the lowest: compound 3; then compound 1; then compound 4; then compound 2.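

In this assay the 3-hydroxypropyl chain does not match the 1H-pyrazol-4-yl group at this amide-type nitrogen (a 2100-fold higher number from compound 3 to compound 4 (3.33 log units; beyond the scatter)), although the two groups have the same counts of hydrogen-bond donors and acceptors, so those counts alone do not set the number here. The chain also gives a lower number than the oxetan-3-yl group (a 7.7-fold lower number from compound 2 to compound 4 (0.88 log units; beyond the scatter)) but a higher number than the 1-methyl-1H-pyrazol-3-yl group (a 3.5-fold higher number from compound 1 to compound 4 (0.55 log units; beyond the scatter)). A group with no ring therefore falls among the ring-bearing groups rather than at the high end, and among these four compounds only the 1H-pyrazol-4-yl group stands far apart.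

Nothing at hand gives a cause for these steps. From the compounds shown here alone, it remains open how a longer chain, or a 3-aminopropyl chain with an amine in place of the hydroxyl, would compare at this nitrogen.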